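The source may hold more compounds than are shown below. What is called first, only, known or untested is meant among the compounds shown, and "the series" means these compounds.

Compound 1 `O=C(Nc1ccccc1)c1ccc(/N=N\c2c[nH]c3ccccc23)cc1` carries an unsubstituted phenyl on the amide nitrogen. In a functional assay on P388 cells (Mus musculus) for inhibition, read by MTT assay, with a stated time of 72 h (on this read-out higher numbers stand for weaker inhibition and lower numbers for stronger inhibition), compound 1 gives "not active" (no number reported), so no single number stands for it, and it cannot be placed on a scale against the others. Within the data shown here, compound 2 `O=C(Nc1cccc(Cl)c1)c1ccc(/N=N\c2c[nH]c3ccccc23)cc1` is the only member of the series with a numerical read-out: in this assay compound 2 gives 267000 nM, a very weak effect. Compound 3 `COc1ccccc1NC(=O)c1ccc(/N=N\c2c[nH]c3ccccc23)cc1` behaves like compound 1; in this assay compound 3 gives "not active" (no number reported). Among the measured compounds shown here, no step between measured compounds can be computed, since only one of the three carries a number.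

Compound 4 `O=C(Nc1cccc([N+](=O)[O-])c1)c1ccc(/N=N\c2c[nH]c3ccccc23)cc1` is not yet measured. It differs from compound 1 by nitro in place of hydrogen on an aromatic carbon. Given that compound 1 shows no measurable inhibition and that compound 2 267000 nM sits at the high end of the range, no step beyond the scatter toward stronger inhibition is expected in this assay; the series as a whole is weak. Compound 4 is estimated at 300000 nM, with a range of 100000 nM to 1000000 nM, and a substantial chance that, like compound 1, it is recorded without a number.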

Compound 4, half-maximal inhibitory concentration: 51900 nM
Beside the measured number, compound 4's estimate is 5.8-fold (0.76 log units) above it, outside the stated range (below it).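

At the aromatic carbon meta to a large group, the choice of substituent now registers in this assay: nitro in place of chloro brings a 5.1-fold lower number from compound 2 to compound 4 (0.71 log units; beyond the scatter) and so gives the series its first measured step, toward stronger inhibition. Compound 4 gives a number where compound 1, with the unsubstituted phenyl, gives "not active" (no number reported) as its entry, so the change from phenyl to 3-nitrophenyl cannot be read as a step of any size, only as a move from no number to a number. Nothing given here bears on why nitro and chloro differ at this carbon.

The compounds shown leave open how an amine or a carboxylic acid at the same carbon would read. They also leave open whether nitro would hold this level on another carbon of that ring.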